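The source may report more compounds than this note shows. Statements on the series, on what has been measured and on what is new or still open speak of the compounds shown alone.

Among the measured compounds shown here, compound 2 `Clc1cccc(-c2cc(-c3ccoc3)cc(-c3ccc(Cl)s3)n2)c1` gives the lowest of the two numbers so far in a functional assay on HeLa cells (Homo sapiens) for cytotoxicity, read by ELISA, with a stated time of 4 days (on this read-out lower numbers stand for stronger inhibition and higher numbers for weaker inhibition), at 23700 nM, while compound 1 `Cc1ccc(-c2cc(-c3ccoc3)cc(-c3ccc(Cl)s3)n2)cc1` gives 28700 nM in this assay; the only measured step, a 1.2-fold lower number from compound 1 to compound 2 (0.08 log units; within the scatter), lies within the scatter. Compound 3 `Clc1ccc(-c2cc(-c3ccoc3)cc(-c3cccnc3)n2)s1` differs from compound 2 by pyridin-3-yl in place of 3-chlorophenyl on an aromatic carbon. For the measured compounds named here, no measured step concerns a pyridin-3-yl group, so no change beyond the scatter is expected from this step, a 1.3-fold higher number from compound 2 to compound 3 (0.10 log units; within the scatter). Compound 3 is therefore estimated to give 30000 nM in this assay, expected between 12000 nM and 80000 nM.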

Compound 3, half-maximal inhibitory concentration: 20000 nM
Compound 3: the middle estimate sits 1.5-fold (0.18 log units) above what was measured, within the range that was stated.
By their numbers in this assay, from the lowest: compounds 3, 2 and 1 (each within the scatter of the next).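

In this assay, the exchange of 3-chlorophenyl for pyridin-3-yl next to the ring nitrogen gives a 1.2-fold lower number from compound 2 to compound 3 (0.07 log units; within the scatter), and the exchange of 4-methylphenyl for pyridin-3-yl gives a 1.4-fold lower number from compound 1 to compound 3 (0.16 log units; within the scatter). This position therefore holds a ring with a hetero atom and a hydrogen-bond acceptor as well as the two carbon-only rings, with no step beyond the scatter. No measured evidence bears on why these numbers stay so close. From the compounds shown here alone, whether an amine or a carboxylic acid at this position would move the number beyond the scatter stays open. So does the effect of replacing the furan-3-yl or 5-chlorothiophen-2-yl group.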